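Changing the group on the amine nitrogen of compound 2

The source may hold more compounds than are shown below. What is called first, only, known or untested is meant among the compounds shown, and "the series" means these compounds.

Among the measured compounds shown here, compound 2 `C=C1[C@@H](OC(C)=O)C[C@@H]2[C@](C)(CO[Si](C)(C)C(C)(C)C)[C@H](OC(C)=O)CC[C@@]2(C)[C@@H]1C[C@@H](Nc1ccc(C(=O)O)cc1)C1=CCOC1=O` gives the lowest of the three numbers measured so far in a functional assay on MCF7 cells (Homo sapiens) for cytotoxicity, read by sulforhodamine B assay; on this read-out lower numbers stand for stronger inhibition and higher numbers for weaker inhibition: compound 2 gives 3990 nM. Its nearest neighbour is compound 1 `C=C1[C@@H](OC(C)=O)C[C@@H]2[C@](C)(COC=O)[C@H](OC(C)=O)CC[C@@]2(C)[C@@H]1C[C@@H](Nc1ccc(Br)cc1)C1=CCOC1=O`, which in this assay gives 11400 nM; the furthest is compound 3 `C=C1[C@@H](OC(C)=O)C[C@@H]2[C@](C)(COC=O)[C@H](OC(C)=O)CC[C@@]2(C)[C@@H]1C[C@@H](Nc1ccc(C(=O)O)cc1)C1=CCOC1=O`, which in this assay gives 41700 nM. The two single-change steps measured are a 10-fold higher number from compound 2 to compound 3 (1.02 log units; beyond the scatter) and a 3.7-fold higher number from compound 1 to compound 3 (0.56 log units; beyond the scatter).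

Compound 4 `C=C1[C@@H](OC(C)=O)C[C@@H]2[C@](C)(CO[Si](C)(C)C(C)(C)C)[C@H](OC(C)=O)CC[C@@]2(C)[C@@H]1C[C@@H](Nc1cccc(OC)c1)C1=CCOC1=O` differs from compound 2 in one place: 3-methoxyphenyl in place of 4-carboxyphenyl on an amine nitrogen. For the measured compounds named here, no measured step alters the group on the amine nitrogen while keeping the rest of compound 2 unchanged. Going by the values given here, the one measured change on that ring, a 3.7-fold higher number from compound 1 to compound 3 (0.56 log units; beyond the scatter), runs toward a carboxy group and gives a higher number; compound 4 runs the other way, away from the carboxy group, toward a 3-methoxyphenyl group that has no measured precedent in this set. Against that single step, and with the remainder of compound 2 retained, a lower number of comparable size is expected for compound 4, though the uncertainty is wide.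

Compound 4 is expected to give about 2500 nM, within 700 nM to 9000 nM. The expected step is a 1.6-fold lower number from compound 2 to compound 4 (0.20 log units; within the scatter).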

Compound 4, half-maximal inhibitory concentration: 28100 nM
Estimate against measurement, compound 4: 11-fold (1.05 log units) below; measured number above the stated range.
By their numbers in this assay, from the lowest: compound 2; then compound 1; then compounds 4 and 3 (each within the scatter of the next).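

Replacing 4-carboxyphenyl with 3-methoxyphenyl on the amine nitrogen gives a 7.0-fold higher number from compound 2 to compound 4 (0.85 log units; beyond the scatter) in this assay, which shows that this position responds to a change of aryl group while the rest of compound 2 stays fixed. The earlier step toward a carboxy group, a 3.7-fold higher number from compound 1 to compound 3 (0.56 log units; beyond the scatter), therefore gives no reliable direction for this different aryl change, made with a different group on the oxygen: here, the compound carrying the carboxy group has the lower number. The compounds shown offer no measured basis for explaining the rise from 4-carboxyphenyl to 3-methoxyphenyl.

This single step changes both the substituent and its place on the aromatic ring, so the contribution of each remains unresolved; 4-methoxyphenyl and 3-carboxyphenyl on the amine nitrogen, with the rest of compound 2 unchanged, would separate them. On these data alone, it also remains open whether the same aryl change would give a step of similar direction and size with the smaller group of 2 heavy atoms on the oxygen, as found in compound 3.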